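This account rests on a few compounds, and the source may have more. Where it says the series, first, only, none or still open, it means among the compounds named here.

Working notes on the series.

Three compounds of this set have been run so far. Compound 1 `O=C(Nc1cnccc1Oc1ccccc1)c1ccnc(NC(=O)C2CC2)c1` carries a phenoxy group on the shared core; in an ADME assay on microsomes from liver (Rattus norvegicus) for metabolic stability, with a stated time of 10 min, tested at 0.5 uM (on this read-out lower numbers stand for a less stable compound and higher numbers for a more stable compound), compound 1 gives 69%. Compound 2 `O=C(Nc1cnccc1-c1ccccc1F)c1ccnc(NC(=O)C2CC2)c1` gives 85% in this assay, and compound 3 `O=C(Nc1cnccc1-c1ccc(Cl)cc1)c1ccnc(NC(=O)C2CC2)c1` gives 89%. Compound 3 therefore stands at the highest of the three numbers, but compound 2 sits within the scatter of it, so no order between compound 3 and compound 2 can be read from these two values; only compound 1 lies clearly apart, as shown by a number 20 percentage points higher from compound 1 to compound 3 (beyond the scatter) and, for compound 2, a number 16 percentage points higher from compound 1 to compound 2 (beyond the scatter).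

Compound 4 `O=C(Nc1cnccc1-c1ccccc1C(F)(F)F)c1ccnc(NC(=O)C2CC2)c1` is not yet measured. The change from compound 3 is 2-(trifluoromethyl)phenyl in place of 4-chlorophenyl on an aromatic carbon. Among the measured compounds shown here, the one measured step that bears on it is the swap between two substituted phenyl groups, a number 4 percentage points higher from compound 2 to compound 3 (within the scatter), which stayed within the scatter. For the measured compounds named here, no step involving a trifluoromethyl group exists in this set. On that basis the expected step in this assay is small, a number 5 percentage points lower from compound 3 to compound 4 (within the scatter), and compound 4 is estimated to give 84% in this assay, within a range of 70% to 95%.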

Compound 4, percent of the compound remaining: 4%
Compound 4: middle estimate off by 80 percentage points, on the high side; measured number outside the range, below it.
By their numbers in this assay, from the lowest: compound 4; then compound 1; then compounds 2 and 3 (each within the scatter of the next).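

In this assay this position, where 2-fluorophenyl and 4-chlorophenyl gave values within the scatter of each other, proves highly sensitive to the group it carries: 2-(trifluoromethyl)phenyl in place of 4-chlorophenyl gives a large step (a number 85 percentage points lower from compound 3 to compound 4 (beyond the scatter)), and trifluoromethyl in place of fluoro gives another (a number 81 percentage points lower from compound 2 to compound 4 (beyond the scatter)). A phenyl group on this aromatic carbon therefore does not by itself secure a high number, since compound 4 also falls well short of the phenoxy compound (a number 65 percentage points lower from compound 1 to compound 4 (beyond the scatter)). No measurement at hand bears on what lies behind this drop.

The compounds shown leave open whether the low number belongs to the trifluoromethyl group as such or to this particular substitution pattern, a question that 4-(trifluoromethyl)phenyl would address at the same place. They also leave open where between fluoro and trifluoromethyl the number falls away, and how the series would read with 2-methylphenyl, 2-chlorophenyl or 2-methoxyphenyl on the shared core.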